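This account rests on a few compounds, and the source may have more. Where it says the series, first, only, none or still open, it means among the compounds named here.

In a functional assay on A2780 cells (Homo sapiens) for inhibition (a higher number here means a weaker inhibitor, a lower number a stronger inhibitor), compound 1 (`CCNC(=O)c1noc(-c2cc(C(C)C)c(O)cc2O)c1-c1cc(CN(CC)CC)no1`) gives 78 nM. Compound 2 (`CCNC(=O)c1noc(-c2cc(C(C)C)c(O)cc2O)c1-c1cc(CN2CCN(C)CC2)no1`) stands at "not determined" (no result reported), so it has no number to serve as a starting point. Compound 3 (`CCNC(=O)c1noc(-c2cc(C(C)C)c(O)cc2O)c1-c1cc(C(=O)OCC)no1`) has not yet been measured. The structural change is ethoxycarbonyl in place of (4-methylpiperazin-1-yl)methyl on an aromatic carbon, with ethoxycarbonyl in place of (4-methylpiperazin-1-yl)methyl on an aromatic carbon. Among the compounds with values here, no measured step covers this exchange. The only anchor in this assay is compound 1 at 78 nM, and no shift beyond the scatter from that level is expected. For compound 3 the estimated value is 90 nM, with an expected range of 25 nM to 320 nM.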

Compound 3, half-maximal inhibitory concentration: 9000 nM
Compound 3: the middle estimate sits 100-fold (2.00 log units) below what was measured, outside the stated range (above it).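

In this assay, the substituent on this aromatic carbon of the five-membered aromatic ring matters: ethoxycarbonyl in place of (diethylamino)methyl gives a 120-fold higher number from compound 1 to compound 3 (2.06 log units; beyond the scatter). The earlier compounds shown here offered no step at this position, and compound 2 still allows no comparison with compound 3, so this single exchange carries the reading. Nothing at hand accounts for the shift.

As far as these compounds go, it remains open whether the weaker inhibition follows from the ester itself or from the loss of the amine. A carboxylic acid or an aminomethyl group at this place would help separate the two.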